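The source may report more compounds than this note shows. Statements on the series, on what has been measured and on what is new or still open speak of the compounds shown alone.

Measured in a functional assay on MIA PaCa-2 cells (Homo sapiens) for inhibition, read by MTT assay, with a stated time of 72 h; on this read-out lower numbers stand for stronger inhibition and higher numbers for weaker inhibition:
- compound 1 `COc1cc(NC(C)CCCNC(=O)NNC(=O)Nc2ccc(F)cc2)c2ncccc2c1`: >= 250000 nM (a limit of the assay)
- compound 2 `COc1cc(NC(C)CCCNC(=O)NNC(=O)Nc2ccc(Br)cc2)c2ncccc2c1`: 231000 nM
- compound 3 `COc1cc(NC(C)CCCNC(=O)NNC(=O)Nc2cccc(C(F)(F)F)c2)c2ncccc2c1`: 5600 nM

Compound 2, at 231000 nM, holds the higher of the two actual numbers. The nearest of these lies a 41-fold lower number from compound 2 to compound 3 (1.62 log units; beyond the scatter). The change to compound 4 `COc1cc(NC(C)CCCNC(=O)Nc2ccc(Cl)cc2)c2ncccc2c1` is 4-chlorophenyl in place of ((4-bromophenyl)carbamoyl)amino on an amide-type nitrogen.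

The measured steps exchange only the phenyl group. Bromo in place of fluoro gave an at least 1.0-fold lower number from compound 1 to compound 2 (0.03 log units; that floor lies within the scatter), and 3-(trifluoromethyl)phenyl in place of 4-bromophenyl gave a 41-fold lower number from compound 2 to compound 3 (1.62 log units; beyond the scatter). Among the measured compounds shown here, no measured step removes ((4-bromophenyl)carbamoyl)amino, so the guidance is weak. With compound 2 already high at 231000 nM, a fall is likelier than a rise. A lower number is expected in this assay, an estimated 5.8-fold lower number from compound 2 to compound 4 (0.76 log units; beyond the scatter). Compound 4 is expected at 40000 nM, with an estimated range of 6000 nM to 200000 nM.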

Compound 4, half-maximal inhibitory concentration: 22000 nM
The estimate for compound 4 lay 1.8-fold (0.26 log units) above the measured number; the measured number falls inside the stated range.
By their numbers in this assay, from the lowest: compound 3; then compound 4; then compound 2. At a limit, above all of these: compound 1.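

The replacement of ((4-bromophenyl)carbamoyl)amino by 4-chlorophenyl on the amide-type nitrogen shows that this position tolerates more than a change of phenyl group in this assay: it gives an 11-fold lower number from compound 2 to compound 4 (1.02 log units; beyond the scatter). Replacing ((4-fluorophenyl)carbamoyl)amino by 4-chlorophenyl gives an at least 11-fold lower number from compound 1 to compound 4 (1.05 log units; beyond the scatter). That step is only a floor, as compound 1 stands at a limit of the assay: the limit of >= 250000 nM in this assay, at which 1 of the 4 values shown sits.

Each step changes the halogen and removes the carbamoylamino unit together, so their separate shares remain unresolved. Going by these compounds, how an amine or a carboxylic acid on the phenyl ring would read here also remains open.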